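Working notes on the aryl-amino variation, compounds 1 to 4

The compounds below may be only part of what the source reports. "The series", "measured", "known", "first", "only" and "open" are said of these compounds alone.

Measured in a functional assay on PC-3 cells (Homo sapiens) for cytotoxicity, read by MTT assay, with a stated time of 72 h; on this read-out higher numbers stand for weaker inhibition and lower numbers for stronger inhibition:
compound 1 `FC(F)(F)c1ccc(CSc2nc(Nc3ccccc3Cl)c3ccccc3n2)cc1`: 20400 nM
compound 2 `O=[N+]([O-])c1ccc(Nc2nc(SCc3ccc(C(F)(F)F)cc3)nc3ccccc23)cc1`: 7900 nM
compound 3 `CCOc1ccc(Nc2nc(SCc3ccc(C(F)(F)F)cc3)nc3ccccc23)cc1`: 32100 nM

Compound 3 holds the highest number of the three measured: a 4.1-fold higher number from compound 2 to compound 3 (0.61 log units; beyond the scatter) lies beyond the scatter, while a 1.6-fold higher number from compound 1 to compound 3 (0.20 log units; within the scatter) does not. Compound 4 `COc1cc(Nc2nc(SCc3ccc(C(F)(F)F)cc3)nc3ccccc23)cc(OC)c1` is not yet measured; it differs from compound 3 in 3,5-dimethoxyphenyl in place of 4-ethoxyphenyl on a nitrogen on an aromatic ring. Among the compounds with values here, no measured step makes this exact change. The steps that vary the same group, a 2.6-fold lower number from compound 1 to compound 2 (0.41 log units; beyond the scatter) and a 4.1-fold higher number from compound 2 to compound 3 (0.61 log units; beyond the scatter), are modest, and compound 1 and compound 3 sit within the scatter of each other. The expected step is therefore a 1.1-fold lower number from compound 3 to compound 4 (0.03 log units; within the scatter), no change beyond the scatter. Compound 4 is estimated at 30000 nM, with a range from 10000 nM to 90000 nM.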

Compound 4, half-maximal inhibitory concentration: > 50000 nM
Compound 4 was reported as a limit; the forecaster's own chance of this, stated with the estimate: 15%; middle value at least 1.6-fold (0.22 log units) away from the limit.
By their numbers in this assay, from the lowest: compound 2; then compounds 1 and 3 (each within the scatter of the next). At a limit, above all of these: compound 4.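

Compound 4 is reported only as a limit in this assay, and this limit marks the top of the values shown: the limit of > 50000 nM in this assay, at which 1 of the 4 values shown sits. On the nitrogen, 3,5-dimethoxyphenyl now separates from two other aryl groups, with an at least 6.3-fold higher number from compound 2 to compound 4 (0.80 log units; beyond the scatter) and an at least 2.4-fold higher number from compound 1 to compound 4 (0.38 log units; beyond the scatter), where compound 1 and compound 3 had stayed within the scatter of each other. Against 4-ethoxyphenyl the change gives only a floor (an at least 1.5-fold higher number from compound 3 to compound 4 (0.19 log units; that floor lies within the scatter)), so its true size stays unresolved.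

Still open, going by these compounds, is how an amine or a carboxylic acid on this phenyl ring would read. On these data alone, a longer alkoxy chain in place of ethoxy is equally open.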